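Antiproliferative series: pyrimidin-2-yl in place of phenyl

The compounds below may be only part of what the source reports. "The series", "measured", "known", "first", "only" and "open" are said of these compounds alone.

Compound 1 `COc1ccc(C[C@@H](O)/C=C/C=C/C(=O)NCc2ccc(Cl)cc2)cc1OC`: 16500 nM
Compound 2 `COc1ccc(C[C@@H](O)/C=C/C=C/C(=O)N2CCN(c3ccccc3)CC2)cc1OC`: 14200 nM
Compound 3 `COc1ccc(C[C@@H](O)/C=C/C=C/C(=O)N2CCN(C(c3ccccc3)c3ccccc3)CC2)cc1OC`: 10600 nM

All three values come from a functional assay on A549 cells (Homo sapiens) for antiproliferative activity, read by sulforhodamine B assay, with a stated time of 48 h; a lower number here means a stronger inhibitor, a higher number a weaker inhibitor. Compound 2, at 14200 nM, stands within the scatter of both compound 1 and compound 3, so these numbers set no order. Compound 4 `COc1ccc(C[C@@H](O)/C=C/C=C/C(=O)N2CCN(c3ncccn3)CC2)cc1OC` carries pyrimidin-2-yl in place of phenyl on an amine nitrogen in a ring. Among the measured compounds shown here, no measured pair differs in one place only, so the series offers no direct precedent for this change. With compound 2 at 14200 nM as the only anchor, no step beyond the scatter is expected in this assay. The expected change is a 1.1-fold higher number from compound 2 to compound 4 (0.05 log units; within the scatter). For compound 4 the estimated value is 16000 nM, with an expected range of 8000 nM to 35000 nM.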

Compound 4, half-maximal inhibitory concentration: 9920 nM
Compound 4: the middle estimate sits 1.6-fold (0.21 log units) above what was measured; the measured number falls inside the stated range.
By their numbers in this assay, from the lowest: compounds 4, 3, 2 and 1 (each within the scatter of the next).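

In this assay, among the compounds shown here, this is the first pair that differs in one place only, and it gives a 1.4-fold lower number from compound 2 to compound 4 (0.16 log units; within the scatter). On this amine nitrogen in a ring, pyrimidin-2-yl in place of phenyl therefore produces no change beyond the scatter, although the entering ring adds hydrogen-bond acceptors. Nothing available explains this result.

From the compounds shown here alone, whether an acetyl, a methyl or a pyridin-2-yl group on that nitrogen would give a step beyond the scatter stays open. A single pair also cannot show whether the exchange behaves the same way elsewhere on the shared core.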